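The source may hold more compounds than are shown below. What is called first, only, known or untested is meant among the compounds shown, and "the series" means these compounds.

Of the compounds shown here, three built on one shared core have so far been tested in a functional assay on B16-F10 cells (Mus musculus) for cytotoxicity; a higher number here means a weaker inhibitor, a lower number a stronger inhibitor. There, compound 1 `O=c1oc2ccccc2c2nc3c(ccc4cc[nH]c43)c(-c3c(Cl)cccc3Cl)c12` gives 70700 nM and compound 2 `Cc1ccc(-c2c3ccc4cc[nH]c4c3nc3c2c(=O)oc2ccccc23)cc1` gives 70700 nM. Compound 3 `COc1ccc(-c2c3ccc4cc[nH]c4c3nc3c2c(=O)oc2ccccc23)cc1`, which carries a 4-methoxyphenyl group, gives 70700 nM, so it stands level with the other two.

The next compound, compound 4 `O=c1oc2ccccc2c2nc3c(ccc4cc[nH]c43)c(-c3ccc(Cl)cc3)c12`, has not yet been measured. Its structure departs from that of compound 3 by one small edit: chloro in place of methoxy on an aromatic carbon. Put another way, the 4-methoxyphenyl group of compound 3 becomes a 4-chlorophenyl group in compound 4.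

For the measured compounds named here, three measured steps bear on this edit. The closest is no change at the digits printed from compound 2 to compound 3 (within the scatter), since it also swaps one small group for another on an aromatic carbon. Two broader exchanges of the whole group on the core, no change at the digits printed from compound 1 to compound 2 (within the scatter) and no change at the digits printed from compound 1 to compound 3 (within the scatter), give the same picture. Going by the values given here, no measured compound carries the 4-chlorophenyl group, however, and three compounds are a thin basis for any prediction.

Among the compounds with values here, with no change at the digits printed from compound 2 to compound 3 (within the scatter) as the nearest precedent, no step beyond the scatter is expected in this assay, in either direction. The estimated outcome is a 1.0-fold lower number from compound 3 to compound 4 (0.00 log units; within the scatter). For compound 4 the expected value is 70000 nM, with an estimated range from 35000 nM to 100000 nM.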

Compound 4, half-maximal inhibitory concentration: 70700 nM
Compound 4: the middle estimate sits 1.0-fold (0.00 log units) below what was measured; measured number inside the range.
By their numbers in this assay, from the lowest: compounds 1, 2, 3 and 4 (each within the scatter of the next).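

In this assay, chloro on this aromatic carbon, para to a large group, reads the same as the groups already tried there, with no change at the digits printed from compound 3 to compound 4 (within the scatter) and no change at the digits printed from compound 2 to compound 4 (within the scatter). The swap from methoxy to chloro removes a hydrogen-bond acceptor and brings in the first chlorine at this place, yet the number stays within the scatter; the 4-chlorophenyl group also matches the 2,6-dichlorophenyl group, with no change at the digits printed from compound 1 to compound 4 (within the scatter). The compounds therefore extend the flat picture to a third small group at this place, but nothing shown explains why all four read alike.

The compounds shown carry only a methyl, a methoxy or a chlorine on the phenyl ring, so it remains open whether an amine, a carboxylic acid or a longer chain such as butyl at this place would give a different number in this assay. Going by these compounds, replacing the phenyl ring with a pyridine or a saturated ring, and editing the shared core itself, are also open, since all four compounds keep a phenyl ring on the same core.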